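The compounds below may be only part of what the source reports. "The series", "measured", "known", "first", "only" and "open" are said of these compounds alone.

Among the compounds with values here, compound 1 `CCOC(=O)C1=C(C)NC(=O)NC1c1cn(-c2ccccc2)nc1-c1ccccc1` is one of three compounds measured in a functional assay on MCF7 cells (Homo sapiens) for inhibition, read by sulforhodamine B assay, with a stated time of 24 h (on this read-out higher numbers stand for weaker inhibition of growth and lower numbers for stronger inhibition of growth), where compound 1 gives 60800 nM. Compound 2 `CC1=C(C(=O)Nc2ccccc2)C(c2cn(-c3ccccc3)nc2-c2ccccc2)NC(=S)N1` gives 88200 nM in this assay, and compound 3 `CC1=C(C(=O)Nc2ccc(Cl)cc2)C(c2cn(-c3ccccc3)nc2-c2ccccc2)NC(=S)N1` gives 34700 nM. The difference between the cores of compound 1 and compound 2 is not broken down here. The change from compound 2 to compound 3, (chloro in place of hydrogen on an aromatic carbon), gave a 2.5-fold lower number from compound 2 to compound 3 (0.41 log units; beyond the scatter). Compound 1 and compound 2 lie within the scatter of each other, as do compound 1 and compound 3. Compound 4 `CCOC(=O)C1=C(C)NC(=O)NC1c1cn(-c2ccccc2)nc1-c1ccc(Cl)cc1` has not yet been measured; it differs from compound 1 by the same change, (chloro in place of hydrogen on an aromatic carbon). Resting on the step seen from compound 2 to compound 3, a 2.5-fold lower number from compound 2 to compound 3 (0.41 log units; beyond the scatter), the expected step is a 2.0-fold lower number from compound 1 to compound 4 (0.31 log units; beyond the scatter). Compound 4 is therefore estimated at 30000 nM, between 12000 nM and 75000 nM.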

Compound 4, concentration for 50% growth inhibition: 68800 nM
For compound 4 the middle estimate is 2.3-fold (0.36 log units) below the measured one, and the stated range covers the measured number.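

In this assay, chloro in place of hydrogen on an aromatic carbon gave a 1.1-fold higher number from compound 1 to compound 4 (0.05 log units; within the scatter), so the change did not carry over in size from one core to the other: the same change on two cores in this assay, a 2.5-fold lower number (0.41 log units; beyond the scatter) from compound 2 to compound 3 and a 1.1-fold higher number (0.05 log units; within the scatter) from compound 1 to compound 4, 2.9-fold (0.46 log units) apart, beyond the scatter of two such steps. The step seen on one core is therefore no reliable guide to the step on the other in this series. With a single pair on each core, this does not show why the two steps part, nor how the change would behave on any further core.

As far as these compounds go, it remains open whether a methoxy group, an amine or a carboxylic acid in place of the chloro would shift the number on either core. Whether such groups would also differ between the cores is equally unsettled.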